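This account rests on a few compounds, and the source may have more. Where it says the series, first, only, none or still open, it means among the compounds named here.

Working notes on the series in a functional assay on QGY cells (Homo sapiens) for cytotoxicity, read by MTT assay, with a stated time of 48 h; on this read-out higher numbers stand for weaker inhibition and lower numbers for stronger inhibition. Among the compounds with values here, compound 1 `COc1cc([C@@H]2C[C@@]2(CO)C(=O)Nc2ccccc2)cc(OC)c1OC` gives 36700 nM, the only actual number so far. Compound 2 `CCOC(=O)[C@]1(C(=O)Nc2ccccc2)C[C@H]1c1cc(OC)c(OC)c(OC)c1` reads > 100000 nM, which is a limit of this assay. Compound 3 `COc1cc([C@H]2C[C@@]2(CO)C(=O)Nc2ccccc2)cc(OC)c1OC` reads > 100000 nM, also a limit. Compound 1 therefore stands alone with a number, while the remaining readings sit at the limit of > 100000 nM in this assay, at which 2 of the 3 values shown sit.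

Within the data shown here, the one measured step is an at least 2.7-fold higher number from compound 1 to compound 3 (0.43 log units; beyond the scatter), and it reflects (the fact that compounds 1 and 3 differ only in the configuration as drawn). It involves no substituent, so it gives no size for the change now in view.

Compound 4 `COc1cc([C@@H]2C[C@@]2(CO)C(=O)Nc2ccccc2Cl)cc(OC)c1OC` is compound 1 with one change: chloro in place of hydrogen on an aromatic carbon. This is chloro in place of hydrogen on an aromatic carbon. Among the measured compounds shown here, no measured compound carries a change at this ring, so neither direction nor size can be read from the data. The expected 1.3-fold lower number from compound 1 to compound 4 (0.12 log units; within the scatter) stays within the scatter, with no firm direction. For compound 4 the estimated value is 28000 nM, with an expected range of 7000 nM to 100000 nM.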

Compound 4, half-maximal inhibitory concentration: 24500 nM
The estimate for compound 4 lay 1.1-fold (0.06 log units) above the measured number; the measured number falls inside the stated range.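

The anilino ring now has its first measured change in this assay, and that change is a 1.5-fold lower number from compound 1 to compound 4 (0.18 log units; within the scatter). Compound 4 therefore still gives a measurable number, and at this place, ortho to a large group, this read-out does not separate chloro from hydrogen. Nothing measured on these compounds bears on this result.

Going by these compounds, whether a methoxy group, an amine or a carboxylic acid in the same place would give a step beyond the scatter remains open. Also open, on these data alone, is whether chloro at another carbon of this six-membered aromatic ring, or on the stereoisomer compound 3, would read the same way as it does on the core of compound 1.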